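A few compounds are considered here, and "the series" means these few. Any claim that something is new, unique, unknown or untested is made for them only; others in the source may bear on it.

Compounds measured so far:
Compound 1, `Oc1cccc(-c2cc(-c3ccsc3)cc(-c3cccc(O)c3)n2)c1`: in a functional assay on HeLa cells (Homo sapiens) for cytotoxicity, read by CCK-8 assay (on this read-out lower numbers stand for stronger inhibition and higher numbers for weaker inhibition), compound 1 gives 16600 nM.
Compound 2, `Oc1ccc(-c2cc(-c3ccsc3)cc(-c3cccc(O)c3)n2)cc1`: in this assay compound 2 gives 2580 nM.
Compound 3, `Oc1ccc(-c2cc(-c3ccsc3)cc(-c3ccc(O)cc3)n2)cc1`: in this assay compound 3 gives 4370 nM.

All three share one core and differ only in where the hydroxyl groups sit on the two phenyl rings. Compound 2 and compound 3 cannot be told apart, since a 1.7-fold higher number from compound 2 to compound 3 (0.23 log units; within the scatter) lies within the scatter. Compound 1, by contrast, stands clearly apart from compound 2: a 6.4-fold lower number from compound 1 to compound 2 (0.81 log units; beyond the scatter) is beyond the scatter.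

Compound 4, `Oc1ccc(-c2cc(-c3ccoc3)cc(-c3cccc(O)c3)n2)cc1`, keeps the two hydroxyphenyl groups of compound 2 and changes only the five-membered ring: furan-3-yl in place of thiophen-3-yl on an aromatic carbon. Neither measured step bears directly on this change; both steps concern the hydroxyphenyl groups, and the thiophene ring is the same in all three measured compounds. The data therefore give no direct guide, and the cautious expectation is a step of no more than the usual scatter in this assay.

Compound 4 is thus estimated at 3500 nM, with a range from 1200 nM to 10000 nM. The expected step is a 1.4-fold higher number from compound 2 to compound 4 (0.13 log units; within the scatter).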

Compound 4, half-maximal inhibitory concentration: 3310 nM
For compound 4 the middle estimate is 1.1-fold (0.02 log units) above the measured one; low and high end bracket the measured number.
By their numbers in this assay, from the lowest: compounds 2, 4 and 3 (each within the scatter of the next); then compound 1.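

Until now the thiophen-3-yl group was the same in every compound, so nothing showed how this position, opposite the ring nitrogen, responds to a change of its five-membered ring. In this assay, furan-3-yl in place of thiophen-3-yl gives a 1.3-fold higher number from compound 2 to compound 4 (0.11 log units; within the scatter), so exchanging the sulfur of the ring for an oxygen, with the ring size and the hydrogen-bond counts unchanged, leaves the number within the scatter of compound 2. No measurement among the data gives a reason for this result.

The compounds shown leave open whether this position tolerates anything other than a five-membered aromatic ring with one hetero atom, such as a plain phenyl ring, an amine or a carboxylic acid. They also leave open whether furan-3-yl would give a similar number alongside the hydroxyl arrangements of compound 1 and compound 3, since the furan ring appears here only with the arrangement of compound 2.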